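Replacing ((quinolin-8-yl)oxy)methyl with 4-fluorophenyl

The source may report more compounds than this note shows. Statements on the series, on what has been measured and on what is new or still open speak of the compounds shown alone.

Measured in a functional assay on HeLa cells (Homo sapiens) for cytotoxicity, read by sulforhodamine B assay, with a stated time of 72 h (on this read-out lower numbers stand for stronger inhibition and higher numbers for weaker inhibition), so far:
Compound 1 `C=C1C(=O)O[C@@H]2CC(C)=C([C@@H](C)CCCOC(C)=O)[C@@H](OC(=O)CCl)[C@H]12` gives 28500 nM
Compound 2 `C=C1C(=O)O[C@@H]2CC(C)=C([C@@H](C)CCCOC(C)=O)[C@@H](OC(=O)COc3cccc4cccnc34)[C@H]12` gives 8940 nM
Compound 3 `C=C1C(=O)O[C@@H]2CC(C)=C([C@@H](C)CCCOC(C)=O)[C@@H](OC(=O)COc3ccc4c(CC)noc4c3)[C@H]12` gives 21700 nM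

Compound 2 has the lowest number of the three, so it inhibits most strongly. Compound 4 `C=C1C(=O)O[C@@H]2CC(C)=C([C@@H](C)CCCOC(C)=O)[C@@H](OC(=O)c3ccc(F)cc3)[C@H]12` differs from it by one swap, 4-fluorophenyl in place of ((quinolin-8-yl)oxy)methyl on a carbonyl carbon. Among the compounds with values here, no measured step makes this exact swap. The closest guides are a 3.2-fold lower number from compound 1 to compound 2 (0.50 log units; beyond the scatter) and a 2.4-fold higher number from compound 2 to compound 3 (0.39 log units; beyond the scatter), both modest and both leaving compound 2 with the lower number. A modest rise is therefore expected in this assay, with the expected size being a 2.2-fold higher number from compound 2 to compound 4 (0.35 log units; beyond the scatter) and no firmer evidence available. The estimate for compound 4 is 20000 nM, with an expected range from 7000 nM to 50000 nM.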

Compound 4, half-maximal inhibitory concentration: 12000 nM
Estimate against measurement, compound 4: 1.7-fold (0.22 log units) above, within the range that was stated.
By their numbers in this assay, from the lowest: compounds 2, 4, 3 and 1 (each within the scatter of the next, the first and the last beyond it).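

In this assay, 4-fluorophenyl on the carbonyl carbon cannot be told apart from the larger ((quinolin-8-yl)oxy)methyl, with a 1.3-fold higher number from compound 2 to compound 4 (0.13 log units; within the scatter) for this swap. Against chloromethyl, the same group gives a 2.4-fold lower number from compound 1 to compound 4 (0.38 log units; beyond the scatter) and so shows that, among these compounds, a number below that of compound 1 does not need the quinoline ring or its linking oxygen. No supporting measurement explains this result.

As far as these compounds go, whether the fluorine contributes remains open, as a plain phenyl would test that directly. A 4-aminophenyl group at this carbonyl carbon is also an open case.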